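From carboxy to ethoxycarbonyl at the limit of toxicity

The compounds below may be only part of what the source reports. "The series", "measured", "known", "first", "only" and "open" are said of these compounds alone.

Compound 1 `Cn1c(=O)c(C(=O)O)c(O)c2cc(Cc3ccccc3)ccc21` gives > 10000 nM in a functional assay on HCT-116 cells (Homo sapiens) for cytotoxicity, read by MTT assay, with a stated time of 72 h (on this read-out lower numbers stand for higher toxicity in this test and higher numbers for lower toxicity in this test), and this is a limit, not a number. Compound 2 `Cn1c(=O)c(C(=O)O)c(O)c2cc(Cc3ccc(F)cc3)ccc21` gives > 10000 nM in this assay, also a limit. Compound 3 `Cn1c(=O)c(C(=O)O)c(O)c2cc(Oc3ccccc3)ccc21` gives > 10000 nM in this assay, again a limit. Compound 1 therefore has no measured number of its own and stands with compound 2 and compound 3 at the limit of > 10000 nM in this assay, at which 3 of the 3 values shown sit.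

Compound 4 `CCOC(=O)c1c(O)c2cc(Cc3ccccc3)ccc2n(C)c1=O` differs from compound 1 by ethyl in place of hydrogen on an oxygen next to a carbonyl group. In words, ethyl takes the place of hydrogen on an oxygen next to a carbonyl group, which also reads as carboxy to ethoxycarbonyl.

Three measured steps are available: a step that the two limits leave unreadable from compound 1 to compound 2, then a step that the two limits leave unreadable from compound 1 to compound 3, and finally a step that the two limits leave unreadable from compound 2 to compound 3. For the measured compounds named here, none of them changes the carboxy group, and none has a readable size, so they offer no measured precedent for this change. Going by the values given here, no step of a known size or firm direction is therefore expected in this assay, and compound 4 is expected to stay close to the limit shared by the other three compounds. The estimate means an expected a number no higher from compound 1 to compound 4 (the limit leaves the size open). For compound 4 the estimated value is 10000 nM, with an expected range from 3000 nM to 30000 nM.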

Compound 4, half-maximal cytotoxic concentration: > 10000 nM
Compound 4: only a limit was reported (the forecaster's own chance of this, stated with the estimate: 65%); the middle value sits exactly at the limit.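

Compound 4 gives > 10000 nM in this assay, and this is a limit. Compound 1 also has only a limit, so no step between compound 1 and compound 4 can be read, and all the compounds stand together: the limit of > 10000 nM in this assay, at which 4 of the 4 values shown sit.

The compounds shown leave open how large the change from carboxy to ethoxycarbonyl is in this assay, and in which direction it runs.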